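A few compounds are considered here, and "the series" means these few. Any claim that something is new, unique, unknown or untested is made for them only; others in the source may bear on it.

Measured so far in a functional assay on A549 cells (Homo sapiens) for cytotoxicity, read by MTT assay, with a stated time of 72 h; a lower number here means a stronger inhibitor, a higher number a weaker inhibitor:

- compound 1, `O=[N+]([O-])c1cccc(COCNc2n[n+]([O-])c3ccccc3[n+]2[O-])c1`: 2890 nM
- compound 2, `CCCCCOCNc1n[n+]([O-])c2ccccc2[n+]1[O-]`: 6460 nM
- compound 3, `CCCCCOCNc1n[n+]([O-])c2cc(OC)ccc2[n+]1[O-]`: 5040 nM

Compound 2 stands highest of the three numbers in this assay. Its nearest neighbour is compound 3, the step being a 1.3-fold lower number from compound 2 to compound 3 (0.11 log units; within the scatter), which is a methoxy in place of hydrogen on an aromatic carbon and so says nothing about the chain. For the measured compounds named here, the furthest is compound 1, whose number lies beyond the scatter from compound 2; no single-point step joins the two, so only the two values themselves speak.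

Compound 4, `CCCCCCCOCNc1n[n+]([O-])c2ccccc2[n+]1[O-]`, differs from compound 2 only on the chain: ethyl in place of hydrogen on a saturated chain carbon, five bonds along the chain from an oxygen on a saturated carbon. Going by the values given here, no measured pair changes the chain length, so there is no step that bears directly on this change; the one measured step, a 1.3-fold lower number from compound 2 to compound 3 (0.11 log units; within the scatter), sits elsewhere on the shared core and is itself within the scatter. With nothing pointing either way, the expectation is no step beyond the scatter in this assay.

Compound 4 is therefore expected to give about 6000 nM, within 2800 nM to 13000 nM. The expected step is a 1.1-fold lower number from compound 2 to compound 4 (0.03 log units; within the scatter), essentially flat.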

Compound 4, half-maximal inhibitory concentration: 2610 nM
The estimate for compound 4 lay 2.3-fold (0.36 log units) above the measured number; the measured number lies below the stated range.
By their numbers in this assay, from the lowest: compounds 4, 1, 3 and 2 (each within the scatter of the next, the first and the last beyond it).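

In this assay the chain is a place that responds: ethyl in place of hydrogen on a saturated chain carbon, five bonds along the chain from an oxygen on a saturated carbon, gives a 2.5-fold lower number from compound 2 to compound 4 (0.39 log units; beyond the scatter) as a step beyond the scatter, while the methoxy change on the aromatic carbon gives a 1.3-fold lower number from compound 2 to compound 3 (0.11 log units; within the scatter) and stays within it. The step is modest and rests on this single pair, so it shows that the number can move with added chain at this carbon, not that it follows chain length. No measurement bearing on the reason for this step is available.

Still open, from the compounds shown here alone, is whether a longer chain moves the number further, or whether an amine or a carboxylic acid at the chain end keeps the step. Also open, going by these compounds, is whether the ethyl and methoxy changes add up on the shared core.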